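The compounds below may be only part of what the source reports. "The series", "measured", "known", "first", "only" and "open" are said of these compounds alone.

Among the compounds with values here, compound 1 `O=c1ccc(-c2ccc3cn[nH]c3c2)cn1Cc1cccc(Cl)c1` is one of two compounds measured in an assay for inhibition of MAP kinase-interacting serine/threonine-protein kinase 1 (Homo sapiens), read by luminescence and ADP-Glo, with a stated time of 2 h (a lower number here means a stronger inhibitor, a higher number a weaker inhibitor), where compound 1 gives 37 nM. The other, compound 2 `O=c1ccc(-c2n[nH]c3ncc(Br)cc23)cn1Cc1ccccc1`, gives in this assay 56 nM, and the two numbers lie within the scatter of each other, so compound 1 stands alongside compound 2 rather than apart from it. Compound 3 `Nc1cccc(Cn2cc(-c3ccc4cn[nH]c4c3)ccc2=O)c1` has not yet been measured; it differs from compound 1 in one place (amino in place of chloro on an aromatic carbon). Within the data shown here, no measured pair here shows how such a change acts, so only a small step is expected, a 1.6-fold higher number from compound 1 to compound 3 (0.21 log units; within the scatter), staying within the scatter. Compound 3 is thus estimated at 60 nM in this assay, within 25 nM to 150 nM.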

Compound 3, half-maximal inhibitory concentration: 287 nM
Compound 3: middle estimate off by 4.8-fold (0.68 log units), on the low side; measured number above the stated range.
By their numbers in this assay, from the lowest: compounds 1 and 2 (each within the scatter of the next); then compound 3.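

In this assay the change from 3-chlorobenzyl to 3-aminobenzyl gives a 7.8-fold higher number from compound 1 to compound 3 (0.89 log units; beyond the scatter) and so lies beyond the scatter. This shows that the group at this place on the ring matters, since replacing one heavy atom, chloro by amino, is enough to weaken the compound. Nothing measured here explains why the number rises.

On these data alone, whether fluoro, methyl, hydroxyl or methoxy at this place would keep the number close to that of compound 1 remains open. So does whether the same change would act alike on the core of compound 2.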